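Hydroxy for carboxy on the aryl ring of compound 3

The source may report more compounds than this note shows. Statements on the series, on what has been measured and on what is new or still open speak of the compounds shown alone.

Among the compounds with values here, compound 3 `CC(C)(C)CCOc1cccc(O)c1C(=O)/C=C/c1ccc(C(=O)O)cc1` is the only member of the series with a number in a functional assay on ACHN cells (Homo sapiens) for antiproliferative activity, read by sulforhodamine B assay; on this read-out lower numbers stand for stronger inhibition of growth and higher numbers for weaker inhibition of growth: compound 3 gives 8450 nM. Compound 1 `CC(C)=CCOc1cccc(O)c1C(=O)/C=C/c1ccc(O)cc1` sits at a limit of that read-out, > 30000 nM. Compound 2 `O=C(/C=C/c1ccc(O)cc1)c1c(O)cccc1OCc1ccccc1` also sits at a limit, > 30000 nM. Within the data shown here, the one step within the measured set, a step that the two limits leave unreadable from compound 1 to compound 2, therefore gives no size. Compound 4 `CC(C)(C)CCOc1cccc(O)c1C(=O)/C=C/c1ccc(O)cc1` keeps the chain of compound 3 and changes the group on the aromatic carbon: hydroxy in place of carboxy on an aromatic carbon The same difference, cut one bond further out, reads 4-carboxyphenyl to 4-hydroxyphenyl. Among the measured compounds shown here, no measured pair shows this exact step, but compound 1 and compound 2 both carry the 4-hydroxyphenyl end and both stand at the limit (the limit of > 30000 nM in this assay, at which 2 of the 3 values shown sit), while the single number belongs to compound 3 with the carboxy group. The expectation for compound 4 is therefore a loss of growth inhibition, a step of a 3.6-fold higher number from compound 3 to compound 4 (0.55 log units; beyond the scatter) that most likely ends at the limit again. Compound 4 is estimated at 30000 nM, within 10000 nM to 100000 nM.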

Compound 4, concentration for 50% growth inhibition: 3140 nM
Estimate against measurement, compound 4: 9.6-fold (0.98 log units) above; measured number below the stated range.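

In this assay, the 4-hydroxyphenyl end gives a measured number once the chain is neopentyl, and hydroxy in place of carboxy on the aromatic carbon improves growth inhibition, a 2.7-fold lower number from compound 3 to compound 4 (0.43 log units; beyond the scatter). With the 4-hydroxyphenyl end held, the chain on the oxygen now shows an effect: neopentyl in place of phenyl gives an at least 9.5-fold lower number from compound 2 to compound 4 (0.98 log units; beyond the scatter), and neopentyl in place of 2-methylprop-1-en-1-yl gives an at least 9.5-fold lower number from compound 1 to compound 4 (0.98 log units; beyond the scatter). Compound 1 and compound 2 stand at a limit, so both chain steps are bounded on one side only and the step between those two compounds cannot be read: the limit of > 30000 nM in this assay, at which 2 of the 4 values shown sit.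

As far as these compounds go, only the neopentyl chain is seen with both carboxy and hydroxy, so whether this order holds on other chains stays open. Also open, from the compounds shown here alone, is what an amine on that aromatic carbon, or a longer saturated chain on the oxygen, would give.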